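A few compounds are considered here, and "the series" means these few. Any claim that something is new, unique, unknown or untested is made for them only; others in the source may bear on it.

Measured in an ADME assay on HepG2 cells (Homo sapiens) for cytotoxicity, in the presence of a further agent that is not named here; on this read-out higher numbers stand for weaker inhibition and lower numbers for stronger inhibition:
compound 1 `O=C(NCc1ccccc1)c1nc(Cc2ccccc2C(F)(F)F)[nH]c(=O)c1O`: > 100000 nM (a limit)
compound 2 `Cn1c(Cc2ccccc2C(F)(F)F)nc(C(=O)NCc2cccnc2)c(O)c1=O`: > 100000 nM (a limit)
compound 3 `Cn1c(Cc2ccccc2C(F)(F)F)nc(C(=O)NCC2CCCCC2)c(O)c1=O`: > 100000 nM (a limit)

Compound 1 stands only at a limit, > 100000 nM, and the same is true of every measured compound: the limit of > 100000 nM in this assay, at which 3 of the 3 values shown sit. Compound 4 `CCn1c(Cc2ccccc2C(F)(F)F)nc(C(=O)NCc2ccccc2)c(O)c1=O` departs from compound 1 by ethyl in place of hydrogen on an aromatic nitrogen. For the measured compounds named here, no measured step covers this change. Going by the values given here, the only step available, a step that the two limits leave unreadable from compound 2 to compound 3, concerns a different place in the molecule and has no readable size. Among the compounds with values here, no step of any particular size or direction can therefore be expected in this assay. The estimated step is a number no higher from compound 1 to compound 4 (the limit leaves the size open), and it is most likely to stay unreadable. For compound 4 the expected value is 100000 nM, within an estimated range from 50000 nM to 200000 nM.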

Compound 4, half-maximal inhibitory concentration: > 100000 nM
Compound 4 was reported as a limit; the forecaster's own chance of this, stated with the estimate: 85%; the middle value lies on the limit itself.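

For the compounds shown here, compound 1 and compound 4 both sit at a limit, and no step between them can be read: the limit of > 100000 nM in this assay, at which 4 of the 4 values shown sit. The compounds shown leave open whether any change on the shared core would give a readable value in this assay.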